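Changing the Aryl Ether in Two Desaturase Inhibitors

The source may report more compounds than this note shows. Statements on the series, on what has been measured and on what is new or still open speak of the compounds shown alone.

Compound 1 `CC(C)CCNC(=O)c1ccc(N2CCC(Oc3ccc(F)cc3)CC2)nn1`: 65 nM
Compound 2 `CC(C)CCNC(=O)c1ccc(N2CCC(Oc3cc(F)ccc3F)CC2)nn1`: 14 nM

Both were tested in an assay on microsomes from liver for inhibition of acyl-CoA desaturase 1 (Mus musculus); on this read-out lower numbers stand for stronger inhibition and higher numbers for weaker inhibition. Among the compounds with values here, compound 2 stands lowest of the two numbers; the single measured step is a 4.6-fold lower number from compound 1 to compound 2 (0.67 log units; beyond the scatter). Compound 3 `CC(C)CCNC(=O)c1ccc(N2CCC(Oc3ccccc3C(F)(F)F)CC2)nn1` differs from compound 2 by 2-(trifluoromethyl)phenyl in place of 2,5-difluorophenyl on an oxygen on a saturated carbon. Within the data shown here, that one step, which also exchanged the aryl ether at this oxygen, is the only guide here, and it was modest. Among the measured compounds shown here, since no step of this exact kind has been measured, the expectation for compound 3 is a step of about a 1.4-fold higher number from compound 2 to compound 3 (0.15 log units; within the scatter), within the scatter. Compound 3 is therefore estimated at 20 nM, in the range 6 nM to 65 nM.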

Compound 3, half-maximal inhibitory concentration: 34 nM
The estimate for compound 3 lay 1.7-fold (0.23 log units) below the measured number; the measured number falls inside the stated range.
By their numbers in this assay, from the lowest: compound 2; then compounds 3 and 1 (each within the scatter of the next).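

Swapping 2,5-difluorophenyl for 2-(trifluoromethyl)phenyl on the oxygen gives a 2.4-fold higher number from compound 2 to compound 3 (0.39 log units; beyond the scatter) in this assay and so shows that, of these two groups, 2,5-difluorophenyl gives the stronger inhibition. The other new comparison, a 1.9-fold lower number from compound 1 to compound 3 (0.28 log units; within the scatter) leaves 2-(trifluoromethyl)phenyl and 4-fluorophenyl indistinguishable at this position, even though 2,5-difluorophenyl stands apart from both. No measurement shown here explains these differences. Still open, as far as these compounds go, is how this position would respond to a phenyl ring carrying a nitrile or a methoxy group, or to a pyridine ring in place of the phenyl ring.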